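Swapping the amine substituent back toward a benzyl group

This account rests on a few compounds, and the source may have more. Where it says the series, first, only, none or still open, it means among the compounds named here.

Measured so far:
- compound 1 `COc1cc(Oc2cccc(Nc3ccccc3)c2)cc(OC)c1CNCc1ccc(F)cc1`: 3640 nM
- compound 2 `COc1cc(Oc2cccc(Nc3ccccc3)c2)cc(OC)c1CN[C@H](C)c1ccccc1`: 7550 nM

In a functional assay on HCT-15 cells (Homo sapiens) for inhibition, read by MTT assay, with a stated time of 72 h (on this read-out lower numbers stand for stronger inhibition and higher numbers for weaker inhibition), compound 2 gives the highest of the two numbers; its nearest neighbour is compound 1, and the step of a 2.1-fold higher number from compound 1 to compound 2 (0.32 log units; beyond the scatter) runs beyond the scatter. Compound 3 `COc1cc(Oc2cccc(Nc3ccccc3)c2)cc(OC)c1CNCc1ccc(Cl)cc1` carries 4-chlorobenzyl in place of 1-phenylethyl on an amine nitrogen. For the measured compounds named here, this largely undoes the change seen from compound 1 to compound 2, exchanging one benzyl-type group for another, so the only bearing step is that one. A lower number is therefore expected, close to compound 1; the estimated step of a 2.2-fold lower number from compound 2 to compound 3 (0.33 log units; beyond the scatter) gives compound 3 a value of 3500 nM, within 1500 nM to 8000 nM.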

Compound 3, half-maximal inhibitory concentration: 4850 nM
Estimate against measurement, compound 3: 1.4-fold (0.14 log units) below, within the range that was stated.
By their numbers in this assay, from the lowest: compounds 1, 3 and 2 (each within the scatter of the next, the first and the last beyond it).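

In this assay, a 1.3-fold higher number from compound 1 to compound 3 (0.12 log units; within the scatter) means that chloro and fluoro on an aromatic carbon of the benzyl group cannot be told apart at this position. With a 1.6-fold lower number from compound 2 to compound 3 (0.19 log units; within the scatter), 4-chlorobenzyl and 1-phenylethyl also cannot be separated, so the gap between compound 1 and compound 2 does not extend to every benzyl group. No measurement shown explains these numbers. Still open, going by these compounds, is how a plain benzyl group or a 4-methoxybenzyl group would read on this amine nitrogen.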